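Aryl group on the ring nitrogen: compound 3 to compound 4

The source may hold more compounds than are shown below. What is called first, only, known or untested is meant among the compounds shown, and "the series" means these compounds.

The series shares one core and varies only the aryl group on an aromatic nitrogen. Compound 1 `N#CC1=C(N)Oc2c(N)cc3nc4ccccc4nc3c2C12C(=O)N(Cc1cnnn1-c1ccccc1Cl)c1ccccc12` carries a 2-chlorophenyl there. In a functional assay on HCT-116 cells (Homo sapiens) for antiproliferative activity, read by MTT assay, with a stated time of 48 h (a higher number here means a weaker inhibitor, a lower number a stronger inhibitor), compound 1 gives > 50000 nM, which is a limit of the assay and not a number. Compound 2 `CCOc1ccc(-n2nncc2CN2C(=O)C3(C(C#N)=C(N)Oc4c(N)cc5nc6ccccc6nc5c43)c3ccccc32)cc1` carries a 4-ethoxyphenyl instead. In this assay compound 2 gives > 50000 nM, again a limit. Compound 3 `Cc1ccc(-n2nncc2CN2C(=O)C3(C(C#N)=C(N)Oc4c(N)cc5nc6ccccc6nc5c43)c3ccccc32)cc1Cl` carries a 3-chloro-4-methylphenyl. In this assay compound 3 gives > 50000 nM, also a limit. Compound 3 therefore stands where every measured member of the series stands, at the limit of > 50000 nM in this assay, at which 3 of the 3 values shown sit. The three steps between them are unreadable: a step that the two limits leave unreadable from compound 1 to compound 2, a step that the two limits leave unreadable from compound 1 to compound 3 and a step that the two limits leave unreadable from compound 2 to compound 3.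

Compound 4 `Cc1ccc(Cl)cc1-n1nncc1CN1C(=O)C2(C(C#N)=C(N)Oc3c(N)cc4nc5ccccc5nc4c32)c2ccccc21` is the next member, differing from compound 3 by 5-chloro-2-methylphenyl in place of 3-chloro-4-methylphenyl on an aromatic nitrogen. Every measured step bears on this change in kind, yet none has a readable size, so no direction can be drawn from them beyond the expectation that compound 4 also stays at the limit. The step from compound 3 to compound 4 is therefore estimated as a step that the limit leaves unreadable from compound 3 to compound 4. For compound 4 the expected value in this assay is 80000 nM, within 20000 nM to 300000 nM, most probably reported only as a limit.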

Compound 4, half-maximal inhibitory concentration: 37200 nM
Beside the measured number, compound 4's estimate is 2.2-fold (0.33 log units) above it, and the stated range covers the measured number.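

The change from compound 3 to compound 4 keeps the same atoms and only rearranges them on the aryl group, yet 5-chloro-2-methylphenyl gives the only value in this assay that is a number and not a limit, while the other members stay at that limit: the limit of > 50000 nM in this assay, at which 3 of the 4 values shown sit.

Against those limits the result can be read only as an at least 1.3-fold lower number from compound 3 to compound 4 (0.12 log units; that floor lies within the scatter), as an at least 1.3-fold lower number from compound 2 to compound 4 (0.12 log units; that floor lies within the scatter) and as an at least 1.3-fold lower number from compound 1 to compound 4 (0.12 log units; that floor lies within the scatter). The aryl group on the aromatic nitrogen thus shows its first readable response in this series, but each step is only a floor within the scatter, so neither a real difference nor its size is established.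

On these data alone, how far compound 1, compound 2 and compound 3 actually lie from compound 4 stays open, and so does whether the methyl or the chlorine of the 5-chloro-2-methylphenyl group accounts for the reading. Also open, as far as these compounds go, is how a 2-methylphenyl without chlorine, or a phenyl carrying an amine or a carboxylic acid, would read in this assay.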